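The source may report more compounds than this note shows. Statements on the series, on what has been measured and on what is new or still open speak of the compounds shown alone.

Working notes on an ADME assay on a cell-free system (plasma, Rattus norvegicus) for protein binding. Going by the values given here, compound 1 (`O=C(O)c1cn(Cc2ccc(-n3cccn3)cc2)c2cccc(F)c2c1=O`) gives 88.4% and compound 2 (`Cc1cn(-c2ccc(Cn3cc(C(=O)O)c(=O)c4c(F)cccc43)cc2)cn1`) gives 88.9%, so compound 2 stands level with the only other measured compound. Next comes compound 3 (`O=C(O)c1cn(Cc2ccc(-n3cnc4ccccc43)cc2)c2cccc(F)c2c1=O`), with 1H-benzimidazol-1-yl in place of 4-methyl-1H-imidazol-1-yl on an aromatic carbon, para to a large group: 1H-benzimidazol-1-yl in place of 4-methyl-1H-imidazol-1-yl on an aromatic carbon. Among the compounds with values here, one measured step bears on this place, a 1.0-fold lower unbound fraction from compound 1 to compound 2 (0.02 log units; within the scatter), with 4-methyl-1H-imidazol-1-yl in place of 1H-pyrazol-1-yl. Within the data shown here, that step stayed within the scatter, but no measured step covers the added six-membered aromatic ring of carbon only, so the support is thin. No step beyond the scatter is expected in this assay, with a slight lean towards less free compound. The estimated step is a 1.4-fold lower unbound fraction from compound 2 to compound 3 (0.14 log units; within the scatter). Compound 3 is estimated at 92%, with a range of 86% to 96.5%.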

Compound 3, plasma protein binding: 91.6%
The estimate for compound 3 lay 1.1-fold (0.02 log units) (unbound fraction) below the measured number, and the stated range covers the measured number.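

At this place, on an aromatic carbon para to a large group, this assay now covers a change that adds a six-membered aromatic ring of carbon only, and 1H-benzimidazol-1-yl gives a 1.3-fold lower unbound fraction from compound 2 to compound 3 (0.12 log units; within the scatter) and also a 1.4-fold lower unbound fraction from compound 1 to compound 3 (0.14 log units; within the scatter). The step from the earlier pair therefore no longer stands alone: a group with more heavy atoms and an extra ring also produces no step beyond the scatter, so all three aromatic groups remain level in this read-out. Nothing on hand offers an explanation for this flat result.

Still open, as far as these compounds go, is whether a different kind of group at this place, such as an amine, a carboxylic acid or a longer alkyl chain, would move the unbound fraction beyond the scatter. Also open, from the compounds shown here alone, is whether these replacements would give similarly small steps on a different core.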